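A few compounds are considered here, and "the series" means these few. Any claim that something is new, unique, unknown or untested is made for them only; others in the source may bear on it.

The account starts from compound 1, whose structure is `Nc1nc(N)c2c(-c3ccsc3)cn([C@@H]3O[C@H](CO)[C@@H](O)[C@H]3O)c2n1`. In a functional assay on HCT-116 cells (Homo sapiens), read by MTT assay, with a stated time of 72 h (a higher number here means a weaker inhibitor, a lower number a stronger inhibitor), compound 1 gives > 20000 nM, and this figure is a limit of the assay rather than a number. That places compound 1 at the limit of > 20000 nM in this assay, at which 1 of the 2 values shown sits. The other measured compound is compound 2, with the structure `C#Cc1cn([C@@H]2O[C@H](CO)[C@@H](O)[C@H]2O)c2ncnc(N(C)C)c12`; in this assay compound 2 gives 180 nM. For the measured compounds named here, no step between compound 1 and compound 2 is laid out here, so their two values stand on their own: one at the limit, the other as a number.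

The unmeasured compound is compound 3, with the structure `COc1nc(N)nc2c1c(-c1ccsc1)cn2[C@@H]1O[C@H](CO)[C@@H](O)[C@H]1O`. Its change from compound 1 is methoxy in place of amino on an aromatic carbon. The amino group leaves and a methoxy group enters, on an aromatic carbon of the six-membered aromatic ring.

Since compound 1 sits at a limit, the direction of the step cannot be read from a number. The writer expects compound 3 to remain weak, with a step of an at least 1.6-fold lower number from compound 1 to compound 3 (0.22 log units; that floor lies within the scatter) that may not reach beyond the scatter. In this assay compound 3 is expected to give 12000 nM, within a range from 2500 nM to 20000 nM.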

Compound 3, half-maximal inhibitory concentration: > 20000 nM
Compound 3 ended at the assay's limit (the forecaster's own chance of this, stated with the estimate: 50%); middle value at least 1.6-fold (0.22 log units) from the limit.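

In this assay compound 3 gives > 20000 nM, which is a limit of the assay and not a number. Compound 1 also stands at a limit, so no step between compound 1 and compound 3 can be read: the limit of > 20000 nM in this assay, at which 2 of the 3 values shown sit.

The compounds shown leave open whether methoxy in place of amino on an aromatic carbon changes the read-out at all.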